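A few compounds are considered here, and "the series" means these few. Any claim that something is new, unique, unknown or untested is made for them only; others in the source may bear on it.

Compound 1 `O=C(Nc1ccccc1C(F)(F)F)C1CCc2ccccc2N1`, compound 2 `CCC(=O)N1c2ccccc2CCC1C(=O)Nc1ccccc1C(F)(F)F` and compound 3 `CCC(=O)N1c2ccccc2CCC1C(=O)Nc1cc(C(F)(F)F)cc(C(F)(F)F)c1` were tested in a functional assay on MDA-MB-231 cells (Homo sapiens) for cytotoxicity, read by sulforhodamine B assay, with a stated time of 72 h; a lower number here means a stronger inhibitor of growth, a higher number a weaker inhibitor of growth. Compound 1 gives 45500 nM. For compound 2 the result is only a limit of the assay, > 80000 nM. Compound 3 gives 7280 nM. Compound 2 and compound 1 differ in one place, (hydrogen in place of propanoyl on a nitrogen on an aromatic ring in a ring), and this change gave an at least 1.7-fold lower number from compound 2 to compound 1 (0.24 log units; that floor lies within the scatter). That step rests on compound 2 sitting at the limit of > 80000 nM in this assay, at which 1 of the 3 values shown sits. The difference between the core of compound 2 and the core of compound 3 is not broken down here. Compound 4 `O=C(Nc1cc(C(F)(F)F)cc(C(F)(F)F)c1)C1CCc2ccccc2N1` has not yet been measured in this assay; it differs from compound 3 by the same change at the same place, (hydrogen in place of propanoyl on a nitrogen on an aromatic ring in a ring). By analogy with an at least 1.7-fold lower number from compound 2 to compound 1 (0.24 log units; that floor lies within the scatter), compound 4 is expected to show a 1.8-fold lower number from compound 3 to compound 4 (0.26 log units; within the scatter). Compound 4 is therefore estimated at 4000 nM, most likely between 1500 nM and 15000 nM.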

Compound 4, concentration for 50% growth inhibition: 8270 nM
Beside the measured number, compound 4's estimate is 2.1-fold (0.32 log units) below it; the measured number falls inside the stated range.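

In this assay, putting hydrogen in place of propanoyl on the second core gave a 1.1-fold higher number from compound 3 to compound 4 (0.06 log units; within the scatter), so on this core the propanoyl group can go without a change that stands out from the usual scatter. This does not show that the change acts alike on both cores: the same change on two cores in this assay, an at least 1.7-fold lower number (0.24 log units; that floor lies within the scatter) from compound 2 to compound 1 and a 1.1-fold higher number (0.06 log units; within the scatter) from compound 3 to compound 4; the limit leaves it open whether they differ. The earlier step gives only a floor, since its starting value for compound 2 is a limit and not a number: the limit of > 80000 nM in this assay, at which 1 of the 4 values shown sits. The compounds shown leave open what a methyl group or a longer acyl chain such as butanoyl would do on that nitrogen. They also leave open how the same change would read with a nitrile or a carboxylic acid in place of trifluoromethyl.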